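This account rests on a few compounds, and the source may have more. Where it says the series, first, only, none or still open, it means among the compounds named here.

Compound 1 `CSc1nc(NCc2ccc(-c3ccccn3)cc2)c2[nH]nc(C(C)C)c2n1` bears hydrogen on the saturated chain carbon bound to a sulfur and, in a functional assay on HT cells (Homo sapiens) for antiproliferative activity, read by fluorescence, with a stated time of 72 h (a higher number here means a weaker inhibitor of growth, a lower number a stronger inhibitor of growth), gives 783 nM. Compound 2 `CC(C)c1n[nH]c2c(NCc3ccc(-c4ccccn4)cc3)nc(SCC(C)(C)N)nc12` carries 1-amino-1-methylethyl at that carbon and in this assay gives 85 nM. Compound 3 `CC(C)c1n[nH]c2c(NCc3ccc(-c4ccccn4)cc3)nc(SCCNC(N)=O)nc12` carries ureidomethyl there and in this assay gives 240 nM, the second highest of the three numbers; the steps of a 3.3-fold lower number from compound 1 to compound 3 (0.51 log units; beyond the scatter) and a 2.8-fold higher number from compound 2 to compound 3 (0.45 log units; beyond the scatter) set it between the other two.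

Compound 4 `CCC(O)CSc1nc(NCc2ccc(-c3ccccn3)cc2)c2[nH]nc(C(C)C)c2n1` differs from compound 3 in one place: 1-hydroxypropyl in place of ureidomethyl on a saturated chain carbon bound to a sulfur. Among the compounds with values here, the steps that bear on this are a 3.3-fold lower number from compound 1 to compound 3 (0.51 log units; beyond the scatter) and a 9.2-fold lower number from compound 1 to compound 2 (0.96 log units; beyond the scatter), which show that a group at this carbon lowers the number, and a 2.8-fold higher number from compound 2 to compound 3 (0.45 log units; beyond the scatter), which shows that the size of the gain depends on the group. Within the data shown here, no measured step introduces a hydroxyl-bearing chain, so the expectation is uncertain. A modest rise is expected, a 1.6-fold higher number from compound 3 to compound 4 (0.20 log units; within the scatter), since compound 3 with its ureidomethyl gives 240 nM and a smaller group is expected to give back part of that gain. Compound 4 is estimated at 380 nM, within a range of 150 nM to 950 nM.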

Compound 4, concentration for 50% growth inhibition: 273 nM
Compound 4: the middle estimate sits 1.4-fold (0.14 log units) above what was measured; low and high end bracket the measured number.
By their numbers in this assay, from the lowest: compound 2; then compounds 3 and 4 (each within the scatter of the next); then compound 1.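

With 1-hydroxypropyl on the saturated chain carbon bound to a sulfur, this assay shows a 2.9-fold lower number from compound 1 to compound 4 (0.46 log units; beyond the scatter) and thus that a group without nitrogen also lowers the number. Ureidomethyl and 1-hydroxypropyl cannot be told apart here, as the exchange gives a 1.1-fold higher number from compound 3 to compound 4 (0.06 log units; within the scatter) and lies within the scatter, whereas a 3.2-fold higher number from compound 2 to compound 4 (0.51 log units; beyond the scatter) keeps 1-amino-1-methylethyl as the group with the lowest number of the four. Nothing shown gives a cause for these differences.

On these data alone, whether the hydroxyl of compound 4 contributes to its gain over compound 1 stays open, and a plain propyl chain at this carbon would speak to that. As far as these compounds go, how an unbranched primary amine, a carboxylic acid or a longer chain would compare with 1-amino-1-methylethyl also remains unknown.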